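Swapping selenium for tellurium on a shared side chain

The source may report more compounds than this note shows. Statements on the series, on what has been measured and on what is new or still open speak of the compounds shown alone.

Of the compounds shown here, three have been measured in a physicochemical assay for lipophilicity, read by HPLC, measured as octanol-water partition; on this read-out higher numbers stand for higher lipophilicity and lower numbers for lower lipophilicity. Compound 1 `COc1ccc(N(CC(=O)NCCC[Te]c2ccccc2)C(=O)CNC(=O)OC(C)(C)C)cc1` gives 4.2. Compound 2 `COc1ccc(N(CC(=O)NCCC[Se]c2ccccc2)C(=O)CNC(=O)OC(C)(C)C)cc1` gives 3.3. Compound 3 `COc1ccc(N(CC(=O)NCCC[Se]c2ccccc2)C(=O)CCSC2=C(C)C(=O)c3ccccc3C2=O)cc1` gives 4.23, the highest of the three, with compound 1 close by and compound 2 well behind.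

Compound 1 and compound 2 differ in one place only: a group of 7 heavy atoms (6 carbon, 1 tellurium; one six-membered aromatic ring of carbon only) in place of a group of 7 heavy atoms (6 carbon, 1 selenium; one six-membered aromatic ring of carbon only), on a saturated chain carbon, three bonds along the chain from an amide-type nitrogen That single exchange brought a number 0.90 log units higher from compound 2 to compound 1 (beyond the scatter). Compound 3 shares the selenium-bearing chain of compound 2 but carries a different core; the difference between the two cores is not broken down here.

Compound 4 `COc1ccc(N(CC(=O)NCCC[Te]c2ccccc2)C(=O)CCSC2=C(C)C(=O)c3ccccc3C2=O)cc1` has not yet been measured in this assay. It is to compound 3 what compound 1 is to compound 2: a group of 7 heavy atoms (6 carbon, 1 tellurium; one six-membered aromatic ring of carbon only) in place of a group of 7 heavy atoms (6 carbon, 1 selenium; one six-membered aromatic ring of carbon only), on a saturated chain carbon, three bonds along the chain from an amide-type nitrogen The place is the same word for word in both pairs, so this is the same change made on a second core.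

Among the measured compounds shown here, only one measured example of the change exists, so the expectation rests on it alone. Because the exchange gave a number 0.90 log units higher from compound 2 to compound 1 (beyond the scatter), a step of similar size is expected here, a number 0.87 log units higher from compound 3 to compound 4 (beyond the scatter). Since compound 3 already sits at 4.23, compound 4 is estimated to land at 5.1, most likely between 4.7 and 5.5. Whether the second core carries the change the same way remains to be seen.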

Compound 4, partition coefficient: 1.97
For compound 4 the middle estimate is 3.13 log units above the measured one; measured number outside the range, below it.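

In this assay, putting the tellurium-bearing group in place of the selenium-bearing group on the second core gave a number 2.26 log units lower from compound 3 to compound 4 (beyond the scatter), while the same exchange on the other core gave a number 0.90 log units higher from compound 2 to compound 1 (beyond the scatter), so one change moved the number in opposite directions. Among the compounds shown here, this shows that, in this series, the result of this change on one core did not carry over to the other in either size or direction, and that a single matched pair was not a safe guide to a second core; with only two pairs, it does not show which result is more typical, or how the change would behave on any further core. Nothing available here explains why the two cores part ways.

The compounds shown leave open whether a third core, such as one carrying an amine or a carboxylic acid, would follow compound 1 or compound 4 when selenium is exchanged for tellurium. They also leave open whether the opposite results persist with a longer chain leading to the selenium or tellurium, or with sulfur in that same place.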